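Compound 3 to compound 4: a methylcarbamoyl ring swap

A few compounds are considered here, and "the series" means these few. Any claim that something is new, unique, unknown or untested is made for them only; others in the source may bear on it.

In a physicochemical assay for solubility, read by LC-MS, in phosphate buffer, with a stated time of 24 h, at pH 7.4 (a lower number here means a less soluble compound, a higher number a more soluble compound), compound 3 `CNC(=O)c1ncc(-c2cnc(NCc3c(F)ccc4c3CCO4)c3cn[nH]c(=O)c23)n1C` gives 5000 nM. Compound 2 `CNC(=O)c1cc(-c2cnc(NCc3c(F)ccc4c3CCO4)c3cn[nH]c(=O)c23)n(C)n1` gives 7000 nM, and the two cannot be separated: the record shows a 1.4-fold lower number from compound 2 to compound 3 (0.15 log units; within the scatter). Compound 1 `O=C1CCCN1c1cnc(NCc2c(F)ccc3c2CCO3)c2cn[nH]c(=O)c12` is reported only as a limit, < 2000 nM. Two steps start from that limit, an at least 3.5-fold higher number from compound 1 to compound 2 (0.54 log units; beyond the scatter) and an at least 2.5-fold higher number from compound 1 to compound 3 (0.39 log units; beyond the scatter), so their sizes are bounds and not exact measures.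

Compound 4 `CNC(=O)c1ccc(-c2cnc(NCc3c(F)ccc4c3CCO4)c3cn[nH]c(=O)c23)c(C)n1` carries the next change on the shared core: 2-methyl-6-(methylcarbamoyl)pyridin-3-yl in place of 1-methyl-2-(methylcarbamoyl)-1H-imidazol-5-yl on an aromatic carbon. Among the measured compounds shown here, the closest precedent is the exchange of one methylcarbamoyl-bearing five-membered ring for another, a 1.4-fold lower number from compound 2 to compound 3 (0.15 log units; within the scatter), so a step within the scatter in this assay is expected here, with a slight lean downward. For the measured compounds named here, no measured step brings in a six-membered aromatic ring, so this precedent is only a loose guide. The expected step is a 1.4-fold lower number from compound 3 to compound 4 (0.15 log units; within the scatter). The estimate for compound 4 is 3500 nM, with an expected range of 1200 nM to 9000 nM.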

Compound 4, solubility: 19000 nM
For compound 4 the middle estimate is 5.4-fold (0.73 log units) below the measured one; the whole stated range lies below it.
By their numbers in this assay, from the lowest: compounds 3 and 2 (each within the scatter of the next); then compound 4. At a limit, below all of these: compound 1.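

In this assay, among the compounds shown here, 2-methyl-6-(methylcarbamoyl)pyridin-3-yl at this position gives the first steps beyond the scatter among the methylcarbamoyl-bearing rings, a 3.8-fold higher number from compound 3 to compound 4 (0.58 log units; beyond the scatter) and a 2.7-fold higher number from compound 2 to compound 4 (0.43 log units; beyond the scatter), whereas the exchange between the two five-membered rings stays within it, a 1.4-fold lower number from compound 2 to compound 3 (0.15 log units; within the scatter). Measured against 2-oxopyrrolidin-1-yl, the change gives an at least 9.5-fold higher number from compound 1 to compound 4 (0.97 log units; beyond the scatter). That size is only a bound because compound 1 stands at a limit: the limit of < 2000 nM in this assay, at which 1 of the 4 values shown sits.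

The compounds shown do not separate the six-membered aromatic ring from the methyl group it carries, as both differ together from compound 3 to compound 4. As far as these compounds go, how the number would read with an amine or a carboxylic acid in place of the methylcarbamoyl group on this pyridine remains open.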